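Swapping the hydrazone aryl: from compound 3 to compound 4

The source may hold more compounds than are shown below. What is called first, only, known or untested is meant among the compounds shown, and "the series" means these compounds.

Measured in a functional assay on MKN-45 cells (Homo sapiens) for cytotoxicity, read by MTT assay, with a stated time of 72 h; a higher number here means a weaker inhibitor, a lower number a stronger inhibitor:
compound 1, `CN(C)CCn1cnnc1-c1cc(Oc2ccc(NC(=O)N/N=C/c3ccccc3O[N+](=O)[O-])cc2F)ccn1`, gives 1020 nM;
compound 2, `COc1cc(/C=N/NC(=O)Nc2ccc(Oc3ccnc(-c4nncn4CCN(C)C)c3)c(F)c2)cc(OC)c1OC`, gives 2900 nM;
compound 3, `CN(C)CCn1cnnc1-c1cc(Oc2ccc(NC(=O)N/N=C/c3c(O)ccc4ccccc34)cc2F)ccn1`, gives 2020 nM.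

Compound 3 sits second highest of the three, within the scatter of both neighbours. Compound 4, `CN(C)CCn1cnnc1-c1cc(Oc2ccc(NC(=O)N/N=C/c3ccc(Cl)cc3)cc2F)ccn1`, differs from it by 4-chlorophenyl in place of 2-hydroxynaphthalen-1-yl on a carbon with a double bond to nitrogen. The same position has been varied in every step seen here: a 2.0-fold higher number from compound 1 to compound 3 (0.30 log units; within the scatter) and a 1.4-fold lower number from compound 2 to compound 3 (0.16 log units; within the scatter) stayed within the scatter, while only a 2.8-fold higher number from compound 1 to compound 2 (0.45 log units; beyond the scatter) went beyond it. All three aryl groups thus land in a narrow band, and the 4-chlorophenyl analogue is expected to do likewise. Compound 4 is estimated at 1500 nM, between 500 nM and 5000 nM. For compound 4 this means an expected 1.3-fold lower number from compound 3 to compound 4 (0.13 log units; within the scatter).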

Compound 4, half-maximal inhibitory concentration: 570 nM
Compound 4: middle estimate off by 2.6-fold (0.42 log units), on the high side; the measured number falls inside the stated range.
By their numbers in this assay, from the lowest: compounds 4, 1, 3 and 2 (each within the scatter of the next, the first and the last beyond it).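

In this assay the 4-chlorophenyl group brings a 3.5-fold lower number from compound 3 to compound 4 (0.55 log units; beyond the scatter) and a 5.1-fold lower number from compound 2 to compound 4 (0.71 log units; beyond the scatter) and so widens the band of numbers at this position beyond what the earlier aryl groups spanned. The remaining step is a 1.8-fold lower number from compound 1 to compound 4 (0.25 log units; within the scatter) so the 4-chlorophenyl and 2-(nitrooxy)phenyl analogues stay together at the low end of the series. Nothing measured here explains why the numbers move at this position.

As far as these compounds go, whether the chlorine itself matters remains open. So does how a plain phenyl, a 4-bromophenyl or an aryl ring carrying an amine or a carboxylic acid would compare.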